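Replacing azepan-3-yl with 2-aminoethyl in Ramos cells

The source may hold more compounds than are shown below. What is called first, only, known or untested is meant among the compounds shown, and "the series" means these compounds.

In a functional assay on Ramos cells (Homo sapiens) for cytotoxicity, read by CCK-8 assay, with a stated time of 72 h (on this read-out lower numbers stand for stronger inhibition and higher numbers for weaker inhibition), compound 1 `Cn1cc(NC(=O)c2cnc3ccc(N[C@@H]4CCNC4)nn23)c(C(F)F)n1` gives 45000 nM and compound 2 `Cn1cc(NC(=O)c2cnc3ccc(N[C@@H]4CCCCNC4)nn23)c(C(F)F)n1` gives 7200 nM, the lower of the two numbers and beyond the scatter of compound 1. Compound 3 `Cn1cc(NC(=O)c2cnc3ccc(NCCN)nn23)c(C(F)F)n1` has not yet been measured. It differs from compound 2 on a nitrogen on an aromatic ring, with 2-aminoethyl in place of azepan-3-yl on a nitrogen on an aromatic ring. Among the compounds with values here, only one measured step bears on this change: a 6.3-fold lower number from compound 1 to compound 2 (0.80 log units; beyond the scatter), a modest move that came with azepan-3-yl in place of pyrrolidin-3-yl at that same place. Within the data shown here, no compound without a ring there has been measured, so this guide is thin. Going back from the seven-membered ring, a modest rise is expected in this assay. The expected change is a 2.8-fold higher number from compound 2 to compound 3 (0.44 log units; beyond the scatter). For compound 3 the estimated value is 20000 nM, with an expected range of 6000 nM to 70000 nM.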

Compound 3, half-maximal inhibitory concentration: > 50000 nM
Compound 3 ended at the assay's limit; the forecaster's own chance of this, stated with the estimate: 15%; middle value at least 2.5-fold (0.39 log units) away from the limit.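

In this assay compound 3 gave a limit of the assay and not a number: the limit of > 50000 nM in this assay, at which 1 of the 3 values shown sits.

Exchanging azepan-3-yl for the open 2-aminoethyl chain on this nitrogen gives an at least 6.9-fold higher number from compound 2 to compound 3 (0.84 log units; beyond the scatter), so the chain does not keep the stronger inhibition seen with azepan-3-yl. Set against the pyrrolidin-3-yl group, the same chain gives an at least 1.1-fold higher number from compound 1 to compound 3 (0.04 log units; that floor lies within the scatter), and this floor allows no order between the two, which shows that carrying a ring at this place does not by itself separate a compound from the open chain.

From the compounds shown here alone, how far compound 3 lies past its limit remains unknown. Also open, going by these compounds, is whether a piperidin-3-yl ring or a longer chain ending in an amine would fall nearer to azepan-3-yl or to 2-aminoethyl at this place.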